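The compounds below may be only part of what the source reports. "The series", "measured", "known", "first", "only" and "open" are said of these compounds alone.

For the measured compounds named here, compound 2 `CC(C)[C@H]1CC[C@H](C)C[C@@H]1O[C@H]1O[C@H](CO[C@@H]2O[C@H](COC(=O)c3ccc(Br)cc3)[C@@H](OC(=O)c3ccc(Br)cc3)[C@H](O)[C@H]2O)[C@@H](O)[C@H](O)[C@H]1O` gives the lowest of the two numbers so far: in a functional assay on MOLT-3 cells (Homo sapiens) for cytotoxicity, read by MTT assay, with a stated time of 72 h (on this read-out lower numbers stand for stronger inhibition and higher numbers for weaker inhibition), compound 2 gives 5800 nM, while compound 1 `CC(C)[C@@H]1CC[C@@H](C)C[C@H]1O[C@@H]1O[C@H](CO[C@@H]2O[C@H](COC(=O)c3ccc(Br)cc3)[C@@H](OC(=O)c3ccc(Br)cc3)[C@H](O)[C@H]2O)[C@@H](O)[C@H](O)[C@H]1O` gives 11400 nM, a difference that is within the scatter, as the step of a 2.0-fold lower number from compound 1 to compound 2 (0.29 log units; within the scatter) shows. Compound 3 `CC(C)[C@@H]1CC[C@@H](C)C[C@H]1O[C@H]1O[C@H](CO[C@@H]2O[C@H](COC(=O)c3ccc(Br)cc3)[C@@H](OC(=O)c3ccc(Br)cc3)[C@H](O)[C@H]2O)[C@@H](O)[C@H](O)[C@H]1O` stands to compound 2 as follows: the two compounds have the same atoms and bonds and differ only in configuration as drawn: 3 of 13 stereo elements differ; a stereocentre at a saturated ring carbon is drawn R in compound 2 and S in compound 3; a stereocentre at a saturated ring carbon is drawn S in compound 2 and R in compound 3; a stereocentre at a saturated ring carbon is drawn S in compound 2 and R in compound 3. Going by the values given here, the only measured step that bears on this is a 2.0-fold lower number from compound 1 to compound 2 (0.29 log units; within the scatter), also a change of configuration only, and it stayed within the scatter. A step of similar size, a 1.4-fold higher number from compound 2 to compound 3 (0.14 log units; within the scatter), is therefore expected, with no clear direction. Compound 3 is estimated at 8000 nM, in the range 3000 nM to 22000 nM.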

Compound 3, half-maximal inhibitory concentration: 10600 nM
The estimate for compound 3 lay 1.3-fold (0.12 log units) below the measured number; measured number inside the range.
By their numbers in this assay, from the lowest: compounds 2, 3 and 1 (each within the scatter of the next).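

With one stereocentre at a saturated ring carbon drawn the other way, this assay shows a 1.1-fold lower number from compound 1 to compound 3 (0.03 log units; within the scatter). With three such centres drawn the other way, it shows a 1.8-fold higher number from compound 2 to compound 3 (0.26 log units; within the scatter). Whether one centre differs or three, the numbers for these compounds therefore stay within the scatter of one another. From the compounds shown here alone, all three compounds share the same atoms and bonds, so the effect of any change other than configuration remains open. Going by these compounds, whether an amine or a carboxylic acid in place of the bromine would give a step beyond the scatter also stays open.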